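Adding a Pyridinylmethoxy Arm to Compound 2

The source may report more compounds than this note shows. Statements on the series, on what has been measured and on what is new or still open speak of the compounds shown alone.

Of the compounds shown here, three with a shared core have been tested in an assay on isolated protein for inhibition of protein tyrosine phosphatase type IVA 3 (Homo sapiens), tested at 5 ug/mL; a lower number here means less inhibition, a higher number more inhibition at the concentration tested (going by the name of the read-out). Compound 2, `O=C1NC(=S)S/C1=C\C=C\c1ccccc1`, is the plainest of them, and in this assay compound 2 gives 37.4%, the lowest of the three numbers. Going by the values given here, compound 1, `O=C1NC(=S)S/C1=C\C=C\c1cc(Br)ccc1OCc1ccccc1Br`, keeps the same chain to its aromatic ring but carries extra substituents; in this assay compound 1 gives 40.3%, a number that stays within the usual scatter of the one for compound 2. Compound 3, `O=C1NC(=S)S/C1=C\c1cc(Br)ccc1OCc1ccccc1Br`, has a shorter chain to its aromatic ring, and in this assay compound 3 gives 65.2%, which lies beyond the scatter above compound 2.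

Compound 4, `O=C1NC(=S)S/C1=C\C=C\c1ccccc1OCc1ccncc1`, has not been measured. It differs from compound 2 in one place: (pyridin-4-yl)methoxy in place of hydrogen on an aromatic carbon. Because compound 1 gives 40.3% after a larger set of additions to the same chain, the step of a number 4.6 percentage points higher from compound 2 to compound 4 (within the scatter) is expected to be small and upward at most, within the scatter. Compound 4 is therefore expected to give about 42%, with a range from 25% to 60%.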

Compound 4, a percentage reported as inhibition, at one concentration (the size of the read-out at that concentration, not a potency): 39.4%
Estimate against measurement, compound 4: 2.6 percentage points above; the range from low to high includes it.
By their numbers in this assay, from the lowest: compounds 2, 4 and 1 (each within the scatter of the next); then compound 3.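

In this assay the swap of hydrogen for (pyridin-4-yl)methoxy on an aromatic carbon, ortho to a large group, amounts to a number 2 percentage points higher from compound 2 to compound 4 (within the scatter) and so gives no readable change. Going by these compounds alone, this is the first comparison in the set of two compounds that differ in one place only, and it shows that an arm of 8 heavy atoms, ending in a six-membered aromatic ring with 1 hetero atom, can sit at this carbon without moving the number beyond the scatter. Nothing measured here speaks to why the number stays within the scatter.

As far as these compounds go, whether a different group at this carbon, such as an amine, a carboxylic acid or a (pyridin-3-yl)methoxy arm, would move the number remains open. Also open, from the compounds shown here alone, is whether (pyridin-4-yl)methoxy would do the same on the shorter chain of compound 3.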